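Hydrazone series on the shared core: outlook for compound 3

The compounds below may be only part of what the source reports. "The series", "measured", "known", "first", "only" and "open" are said of these compounds alone.

Compound 1 `Clc1ccccc1CSc1nnc(-c2ccncc2)n1-c1ccccc1` and compound 2 `O=C(CSc1nnc(-c2ccncc2)n1-c1ccccc1)N/N=C/c1ccccc1` share one core. In a functional assay on HCT-116 cells (Homo sapiens) for inhibition, read by MTT assay, with a stated time of 48 h (on this read-out lower numbers stand for stronger inhibition and higher numbers for weaker inhibition), compound 1 gives 13900 nM. Compound 2 gives 14700 nM, which puts it at the top of the two numbers, though its gap to compound 1 lies within the scatter and carries no order. Compound 3 `O=C(CSc1nnc(-c2ccncc2)n1-c1ccccc1)N/N=C/c1cc(Br)ccc1O` differs from compound 2 by 5-bromo-2-hydroxyphenyl in place of phenyl on a carbon with a double bond to nitrogen. Going by the values given here, no measured pair shows this change, so its size is open. A step toward a lower number in this assay is expected for compound 3, a 1.8-fold lower number from compound 2 to compound 3 (0.26 log units; within the scatter), of about the scatter's size. Compound 3 is estimated at 8000 nM, within 3000 nM to 20000 nM.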

Compound 3, half-maximal inhibitory concentration: 1990 nM
Beside the measured number, compound 3's estimate is 4.0-fold (0.60 log units) above it, and the stated range ends above it.
By their numbers in this assay, from the lowest: compound 3; then compounds 1 and 2 (each within the scatter of the next).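

In this assay, going by these compounds alone, the swap of phenyl for 5-bromo-2-hydroxyphenyl on a carbon with a double bond to nitrogen gives a 7.4-fold lower number from compound 2 to compound 3 (0.87 log units; beyond the scatter) and is the first single-place change read. It shows that the number responds to the group at this place, which compounds 1 and 2 alone could not show. Nothing available accounts for the size of this step.

From the compounds shown here alone, the bromine and the hydroxyl enter together, and their separate shares in the step stay open. Going by these compounds, how a phenyl bearing an amine or a carboxylic acid would read at this place also stays open.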